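The source may report more compounds than this note shows. Statements on the series, on what has been measured and on what is new or still open speak of the compounds shown alone.

Measured in an ADME assay on microsomes from liver (Homo sapiens) for metabolic stability, with a stated time of 10 min; on this read-out higher numbers stand for a more stable compound and lower numbers for a less stable compound:
Compound 1 `CS(=O)(=O)C1CCC(C(=O)N2CC[C@](c3ccc(C(F)(C(F)(F)F)C(F)(F)F)cc3)(S(=O)(=O)c3ccc(F)cc3)C2)CC1` gives 88%; 100% (2 entries)
Compound 2 `O=C(C1CCS(=O)(=O)CC1)N1CC[C@](c2ccc(C(F)(C(F)(F)F)C(F)(F)F)cc2)(S(=O)(=O)c2ccc(F)cc2)C1` gives 93%

Among the measured compounds shown here, of these, compound 2 holds the only single number in this assay, at 93%, which lies high on the scale of compound remaining. Compound 1 has no single number, only (the several entries of compound 1 in this assay, 88%; 100% (2 entries)), and both of those entries also lie high on that scale.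

The next compound to be tested is compound 3 `CCC1(C(=O)N2CC[C@](c3ccc(C(F)(C(F)(F)F)C(F)(F)F)cc3)(S(=O)(=O)c3ccc(F)cc3)C2)CCS(=O)(=O)CC1`. It keeps everything in compound 2 except one place: ethyl in place of hydrogen on a saturated ring carbon.

For the measured compounds named here, no measured pair in this small set shows what such a change does in this assay, so the expectation rests on the starting point alone. With compound 2 at 93%, a small downward move is expected, and none beyond the usual scatter. The estimated size of the change is a number 4 percentage points lower from compound 2 to compound 3 (within the scatter). For compound 3 the expected value is 89%, with an estimated range from 72% to 100%.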

Compound 3, percent of the compound remaining: 3%
Estimate against measurement, compound 3: 86 percentage points above; measured number outside the range, below it.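

In this assay, among the compounds shown here, ethyl in place of hydrogen on the saturated ring carbon three ring bonds from the ring sulfur gives the only step that can be read here, a number 90 percentage points lower from compound 2 to compound 3 (beyond the scatter), and it is a large one. The position is thus far from indifferent to this change: the rest of compound 3 is the same as in compound 2, yet the read-out moves from the top of the scale to the bottom, so the high value of compound 2 gave no sign of how much this one ring carbon matters. No measurement among the compounds shown bears on why the value falls so far.

The compounds shown leave open whether the fall in this assay belongs to ethyl itself or would also follow from another group on the same ring carbon, such as methyl, a longer chain, hydroxyl or fluorine. They also leave open whether the same change would act alike on the ring of compound 1, which carries methylsulfonyl and holds no ring sulfur.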